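This account rests on a few compounds, and the source may have more. Where it says the series, first, only, none or still open, it means among the compounds named here.

Measured so far in a functional assay on FaDu cells (Homo sapiens) for inhibition, read by sulforhodamine B assay; a higher number here means a weaker inhibitor, a lower number a stronger inhibitor:
compound 1, `COC(=O)CC/C(C)=C/Cc1c(OC)c(C)c2c(c1OCC#CCN1CCN(c3ccccc3OC)CC1)C(=O)OC2`: > 50000 nM
compound 2, `COC(=O)CC/C(C)=C/Cc1c(OC)c(C)c2c(c1OCC#CCN1CCCc3ccccc31)C(=O)OC2`: > 50000 nM

Compound 1 gives only a limit of the assay, not a number, in this assay. Compound 2 likewise gives only a limit there, > 50000 nM. As the limit of > 50000 nM in this assay, at which 2 of the 2 values shown sit, shows, every value in this small set sits at that same limit, so the numbers place compound 2 neither above nor below compound 1; both are simply too weak to be resolved.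

Compound 3 `COC(=O)CC/C(C)=C/Cc1c(OC)c(C)c2c(c1OCC#CCN1CCC(C(=O)OC)CC1)C(=O)OC2` is not yet measured. It differs from compound 2 in one place: 4-(methoxycarbonyl)piperidin-1-yl in place of 1,2,3,4-tetrahydroquinolin-1-yl on a saturated chain carbon bound to a triple-bonded carbon. Nothing in the measured pair tells how this exchange of one amine for another acts, since the earlier exchange of a 2-methoxyphenylpiperazine for a tetrahydroquinoline left both compounds at the limit.

The step of a number no higher from compound 2 to compound 3 (the limit leaves the size open) is therefore expected to be none beyond the scatter. Compound 3 is expected to give roughly 50000 nM in this assay, within a range from 20000 nM to 100000 nM, and most probably it will again be reported only as a limit.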

Compound 3, half-maximal inhibitory concentration: > 50000 nM
Compound 3 ended at the assay's limit; the forecaster's own chance of this, stated with the estimate: 80%; the middle value lies on the limit itself.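

Compound 3 gives > 50000 nM in this assay, which is a limit of the assay and not a number. No step from compound 2 to compound 3 can be read, because both stand at the same limit: the limit of > 50000 nM in this assay, at which 3 of the 3 values shown sit.

The compounds shown leave open whether exchanging one amine for another changes inhibition in this assay at all.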